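Compound 3 to compound 4: sulfonyl in place of carbonyl

The compounds below may be only part of what the source reports. "The series", "measured", "known", "first", "only" and "open" are said of these compounds alone.

Values in a functional assay on HeLa cells (Homo sapiens) for antiproliferative activity, read by MTT assay, with a stated time of 48 h (on this read-out higher numbers stand for weaker inhibition and lower numbers for stronger inhibition), so far
compound 1 `Cn1cc(-c2cnc3ccc(NC(=O)c4ccc(F)cc4)nc3c2)cn1` gives > 50000 nM (a limit)
compound 2 `COc1ccc(C(=O)Nc2ccc3ncc(-c4cnn(C)c4)cc3n2)cc1` gives 4900 nM
compound 3 `Cn1cc(-c2cnc3ccc(NC(=O)c4cccnc4)nc3c2)cn1` gives > 50000 nM (a limit)

Compound 3 stands at > 50000 nM (a limit, not a number). The series therefore shows the limit of > 50000 nM in this assay, at which 2 of the 3 values shown sit (compound 1 and compound 3), and only compound 2 gives a readable number.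

Among the measured compounds shown here, compound 4 `Cn1cc(-c2cnc3ccc(NS(=O)(=O)c4cccs4)nc3c2)cn1` carries (thiophen-2-yl)sulfonyl in place of (pyridin-3-yl)carbonyl on a nitrogen on an aromatic ring and has no measurement yet.

Two steps are beyond the scatter: an at least 10-fold lower number from compound 1 to compound 2 (1.00 log units; beyond the scatter) with methoxy in place of fluoro, and an at least 10-fold higher number from compound 2 to compound 3 (1.00 log units; beyond the scatter) with pyridin-3-yl in place of 4-methoxyphenyl. The third is a step that the two limits leave unreadable from compound 1 to compound 3 and gives no size. None of them replaces the carbonyl with a sulfonyl, so they set no firm size for this change.

With most of the series at the limit, only a small move toward a lower number is expected in this assay and a result at the limit is just as likely. The expected step is an at least 1.6-fold lower number from compound 3 to compound 4 (0.22 log units; that floor lies within the scatter) and its size remains uncertain. Compound 4 is estimated at 30000 nM with an expected range from 5000 nM to 80000 nM in the same read-out.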

Compound 4, half-maximal inhibitory concentration: 38400 nM
Compound 4: the middle estimate sits 1.3-fold (0.11 log units) below what was measured; the range from low to high includes it.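

In this assay, this nitrogen on an aromatic ring tolerates (thiophen-2-yl)sulfonyl in place of (pyridin-3-yl)carbonyl and yields a readable number, with an at least 1.3-fold lower number from compound 3 to compound 4 (0.11 log units; that floor lies within the scatter). The value of compound 3, > 50000 nM, is a limit, so this step has only a floor and its true size cannot be read. Compound 4 thus shows that a readable value at this position does not require a carbonyl or the 4-methoxyphenyl group of compound 2, although the limit remains common in the series: the limit of > 50000 nM in this assay, at which 2 of the 4 values shown sit.

The step changes the link and the ring together, so the share of the sulfonyl and the share of the thiophene remain unseparated. Also open, going by these compounds, is how a sulfonyl carrying 4-methoxyphenyl, or a carboxylic acid or an amine on the aromatic ring of the carbonyl series, would read.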